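Swapping the ring system on the carbonyl of compound 1

A few compounds are considered here, and "the series" means these few. Any claim that something is new, unique, unknown or untested is made for them only; others in the source may bear on it.

Compound 1 `O=C(NCc1ccc(S(=O)(=O)N2CCCCC2)cc1)c1cc2cnccc2s1` was tested in an ADME assay on microsomes from liver (Mus musculus) for metabolic stability, read by LC-MS, with a stated time of 30 min, tested at 1 uM; a lower number here means that less of the compound is left, a higher number that more of the compound is left. In this assay compound 1 gives "below limit of detection" (no number reported), so no number stands for it. Two other compounds give numbers for comparison. In this assay compound 2 `O=C(NCc1ccc(S(=O)(=O)c2ccc(F)c(F)c2)cc1)c1cc2cnccc2[nH]1` gives 58%. In this assay compound 3 `O=C(NCc1ccc(S(=O)(=O)c2ccccc2)cc1)c1cc2ccncc2s1` gives 21%. Compound 4 `O=C(NCc1ccc(S(=O)(=O)N2CCCCC2)cc1)c1cnc2nccn2c1` has not been measured. It differs from compound 1 at one place, on a carbonyl carbon: a group of 9 heavy atoms (6 carbon, 3 nitrogen; one five-membered aromatic ring with 2 hetero atoms, one six-membered aromatic ring with 2 hetero atoms) in place of a group of 9 heavy atoms (7 carbon, 1 nitrogen, 1 sulfur; one five-membered aromatic ring with 1 hetero atom, one six-membered aromatic ring with 1 hetero atom), on a carbonyl carbon. Going by the values given here, no measured step is known for this exact change, so the expectation has to rest on the numbers seen so far. Since compound 1 gives "below limit of detection" (no number reported), almost any measurable number for compound 4 would lie above it, and a moderate rise beyond the scatter is expected rather than none, though a second reading without a reported number remains possible. The estimate for compound 4 in this assay is 20%, with a plausible range from 0% to 55%.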

Compound 4, percent of the compound remaining: 0.28%
Estimate against measurement, compound 4: 19.7 percentage points above; the range from low to high includes it.
By their numbers in this assay, from the lowest: compound 4; then compound 3; then compound 2.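

Compound 1 has no number in this assay, so the change to compound 4 cannot be read as a step. The compounds shown leave open whether swapping this ring system alters the amount of compound remaining, and no measured evidence bears on the result.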